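A Second Methoxy Enters the Aryl Ring of Compound 1

The compounds below may be only part of what the source reports. "The series", "measured", "known", "first", "only" and "open" are said of these compounds alone.

Compound 1 `COc1ccc(-c2cc(/C=C/C(=O)c3ccc(N)cc3)[nH]n2)cc1` stands at the lowest of the three numbers recorded in a functional assay on MOLT-4 cells (Homo sapiens) for cytotoxicity, read by sulforhodamine B assay, with a stated time of 48 h, tested at 100 uM (a higher number here means a weaker effect of the compound at the concentration tested, a lower number a stronger effect), giving -47%. Compound 2 `COc1cc(-c2cc(/C=C/C(=O)c3ccc(Cl)c(Cl)c3)[nH]n2)cc(OC)c1OC` gives -15% and compound 3 `COc1cc(-c2cc(/C=C/C(=O)c3ccc(F)c(F)c3)[nH]n2)cc(OC)c1OC` gives -14%; both lie beyond the scatter from compound 1, but each differs from it in more than one place, so their values show only that they sit higher. Within the data shown here, the single step that is recorded, a number 1 percentage points higher from compound 2 to compound 3 (within the scatter), concerns the ring on the carbonyl carbon and falls within the scatter; it does not touch the change now in hand. Compound 4 `COc1ccc(-c2cc(/C=C/C(=O)c3ccc(N)cc3)[nH]n2)cc1OC` differs from compound 1 by methoxy in place of hydrogen on an aromatic carbon, ortho to a methoxy group and meta to a large group. Among the measured compounds shown here, no measured pair isolates a methoxy entering this ring, so there is nothing to suggest a shift. For compound 4 the expected step is a number 2 percentage points higher from compound 1 to compound 4 (within the scatter), none beyond the scatter. Compound 4 is therefore estimated at about -45%, within a range from -70% to -20%.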

Compound 4, a percentage reported as activity, at one concentration (the size of the read-out at that concentration, not a potency): -22%
For compound 4 the middle estimate is 23 percentage points below the measured one; the range from low to high includes it.
By their numbers in this assay, from the lowest: compound 1; then compounds 4, 2 and 3 (each within the scatter of the next).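

Methoxy in place of hydrogen on this aromatic carbon, ortho to a methoxy group and meta to a large group, moves the read-out in this assay beyond the scatter, with a number 25 percentage points higher from compound 1 to compound 4 (beyond the scatter). The only earlier single change, on the ring at the carbonyl carbon, gave a number 1 percentage points higher from compound 2 to compound 3 (within the scatter), so this position is the first shown where one change alters the read-out, and here the added methoxy weakens the effect at the concentration tested. Nothing available explains this shift.

The compounds shown leave open whether the step belongs to methoxy itself or would also follow from a hydroxyl, a chlorine or an ethoxy on the same carbon. They also leave open whether the step would keep its size if the amine of compound 1 gave way to a carboxylic acid.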